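The source may report more compounds than this note shows. Statements on the series, on what has been measured and on what is new or still open speak of the compounds shown alone.

In an assay on isolated protein for inhibition of Alpha glucosidase (Homo sapiens), read by spectrophotometry, with stated times of 15 min and 30 min (a higher number here means a weaker inhibitor, a lower number a stronger inhibitor), compound 1 `COc1cc(/C=C2\SC(=O)NC2=O)ccc1OCN1C(=O)c2ccccc2C1=O` gives 35100 nM. Compound 2 `O=C1NC(=O)/C(=C/c2cccc(OCN3C(=O)c4ccccc4C3=O)c2)S1` reaches only the limit of this assay, > 100000 nM, so no number is known for it. Among the measured compounds shown here, compound 3 `COc1cc(/C=C2\SC(=S)NC2=O)ccc1OCN1C(=O)c2ccccc2C1=O` gives 16100 nM, the lowest of the two numbers known here; the only change between the two, a thione in place of the carbonyl of the five-membered ring, brings a 2.2-fold lower number from compound 1 to compound 3 (0.34 log units; beyond the scatter). The limit seen for compound 2 is one shown for this assay (the limit of > 100000 nM in this assay, at which 1 of the 3 values shown sits).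

Compound 4 `O=C1NC(=S)S/C1=C\c1ccc(OCN2C(=O)c3ccccc3C2=O)cc1` differs from compound 3 in one place: hydrogen in place of methoxy on an aromatic carbon. For the measured compounds named here, none of the measured steps removes a methoxy, so nothing measured here tells how large that step should be; the only measured step, from compound 1 to compound 3, concerns the five-membered ring and is modest in size. Compound 2, which also lacks the methoxy but carries its large group in another place, gives only a limit, which leaves the effect of the methoxy itself open. For compound 4 the expectation is therefore a step of a 1.6-fold higher number from compound 3 to compound 4 (0.19 log units; within the scatter), at most a small weakening, within or just beyond the scatter. Compound 4 is estimated at 25000 nM, with a likely range from 10000 nM to 70000 nM.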

Compound 4, half-maximal inhibitory concentration: 7910 nM
The estimate for compound 4 lay 3.2-fold (0.50 log units) above the measured number, and the stated range ends above it.
By their numbers in this assay, from the lowest: compound 4; then compound 3; then compound 1. At a limit, above all of these: compound 2.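

In this assay the loss of the methoxy can now be read as a step of its own, and it comes out as a 2.0-fold lower number from compound 3 to compound 4 (0.31 log units; beyond the scatter) in the direction of a stronger inhibitor. The methoxy on this aromatic carbon, ortho to a large group, is therefore not needed for the inhibition seen with compound 3, and plain hydrogen does better there, though only modestly. This rests on a single pair of compounds that share the thione ring, so it is a finding about that pair and not yet a rule for the position.

As far as these compounds go, whether hydrogen would also beat methoxy with the carbonyl ring of compound 1 stays open, and so does the effect of other groups at this place, such as fluorine, a hydroxyl or an ethoxy. Nothing measured in this set explains why removing the methoxy lowers the number.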